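Pyridinyl hydrazone in place of the dimethylphenyl group

This account rests on a few compounds, and the source may have more. Where it says the series, first, only, none or still open, it means among the compounds named here.

In a functional assay on the whole organism with Rattus norvegicus as the target (on this read-out higher numbers stand for an effect only at larger amounts of compound and lower numbers for an effect already at smaller amounts), compound 1 `Cc1cccc(C)c1NN=C1CCC(C)n2c1ncc(C(=O)O)c2=O` gives 320 umol/kg. It stands level with compound 2 `Cc1cc(C)c(NN=C2CCC(C)n3c2ncc(C(=O)O)c3=O)c(C)c1`, which gives 320 umol/kg in this assay, and the step of no change at the digits printed from compound 1 to compound 2 (within the scatter) lies within the scatter. For compound 3 `CC1CCC(=NNc2cc(C(F)(F)F)cc(C(F)(F)F)c2)c2ncc(C(=O)O)c(=O)n21` the result in this assay is a limit, > 100 umol/kg, as the limit of > 100 umol/kg in this assay, at which 1 of the 3 values shown sits, records. Compound 4 `CC1CCC(=NNc2ccccn2)c2ncc(C(=O)O)c(=O)n21` differs from compound 1 by pyridin-2-yl in place of 2,6-dimethylphenyl on an amine nitrogen. Among the compounds with values here, no measured step touches this group; the only measured step, no change at the digits printed from compound 1 to compound 2 (within the scatter), concerns a methyl on an aromatic carbon and brought no change. The step of no change at the digits printed from compound 1 to compound 4 (within the scatter) is therefore expected to be small, of uncertain direction, with the range left wide. Compound 4 is estimated at 320 umol/kg, within 100 umol/kg to 1000 umol/kg.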

Compound 4, dose for 50% inhibition: > 100 umol/kg
Compound 4: a limit, no number; the forecaster's own chance of this, stated with the estimate: 30%; the middle value does not contradict the limit.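

In this assay compound 4 gives a limit, > 100 umol/kg, so its step from compound 1 cannot be read. The compounds shown leave open whether pyridin-2-yl in place of 2,6-dimethylphenyl changes the read-out at all, and in which direction.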